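Swapping a Chain for a Ring at the Amide Carbonyl

The source may hold more compounds than are shown below. What is called first, only, known or untested is meant among the compounds shown, and "the series" means these compounds.

Compound 1 `CN(CCCn1ccnc1)C(=O)[C@@H]1CCCN1c1nccc(Nc2ccccc2)n1`: 5%
Compound 2 `CC(=O)CCCCC(=O)N1CCN(c2nccc(Oc3cccc(C)c3)n2)CC1`: 0%
Compound 3 `COC[C@@H]1CCCN1C(=O)C1CCCN1c1cc(Nc2cccc(Br)c2)ncn1`: 3%

Of the compounds shown here, three have been tested in an assay on isolated protein for inhibition of serine/threonine-protein kinase Chk2 (Homo sapiens), read by HTRF, tested at 10 uM; a higher number here means more inhibition at the concentration tested (going by the name of the read-out), a lower number less inhibition. Compound 1 gives 5%, compound 3 gives 3%, and compound 2 gives 0%. None of the three numbers is separated from that of compound 2 by more than the usual scatter of repeated measurements, so in this assay the three sit together near the bottom of the scale, with no real gap between them.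

The step under consideration goes from compound 2 to compound 4 `Cc1cccc(Oc2ccnc(N3CCN(C(=O)c4c(C)noc4C)CC3)n2)c1`. The change sits on the carbonyl carbon whose other neighbour is an amide-type nitrogen in a ring: 3,5-dimethyl-1,2-oxazol-4-yl in place of 4-acetylbutyl on a carbonyl carbon. Cut one bond further out, the same difference reads (4-acetylbutyl)carbonyl to (3,5-dimethyl-1,2-oxazol-4-yl)carbonyl.

Within the data shown here, no step between two measured compounds is available to show how a change of this kind moves the read-out, so the expectation rests on the measured compounds alone. Since compound 2 gives 0% and the others lie within the scatter of it, no step beyond the scatter is expected from compound 2 to compound 4, which would be a number 5 percentage points higher from compound 2 to compound 4 (within the scatter). Compound 4 is therefore estimated at 5%, within a range from 0% to 20%.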

Compound 4, a percentage reported as inhibition, at one concentration (the size of the read-out at that concentration, not a potency): 3%
Compound 4: the middle estimate sits 2 percentage points above what was measured; the measured number falls inside the stated range.
By their numbers in this assay, from the lowest: compounds 2, 3, 4 and 1 (each within the scatter of the next).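

Among these compounds, compounds 2 and 4 differ in only one place, so this pair gives the first direct reading of a change at the carbonyl carbon. In this assay, putting 3,5-dimethyl-1,2-oxazol-4-yl in place of 4-acetylbutyl gives a number 3 percentage points higher from compound 2 to compound 4 (within the scatter). Both groups hold 7 heavy atoms, so this pair shows that exchanging a chain with no ring for a five-membered aromatic ring of the same heavy-atom count, with 2 hydrogen-bond acceptors in place of 1, does not produce a step beyond the scatter; no measurement shown accounts for this outcome, and no explanation can be offered for it.

From the compounds shown here alone, whether a different group on this carbonyl carbon, such as a short chain ending in an amine or a longer chain ending in a carboxylic acid, would give a step beyond the scatter remains open. Also open, going by these compounds, is how the same exchange would read in a compound with a clearly higher number in this assay, as a single pair near the bottom of the scale cannot settle that.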